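The source may hold more compounds than are shown below. What is called first, only, known or untested is meant among the compounds shown, and "the series" means these compounds.

Compound 1: `c1ccc(C(CCn2ccnc2)c2ccccc2)cc1`, 89.1 nM. Compound 2: `NC(=O)C(CCn1ccnc1)(c1ccccc1)c1ccccc1`, 5.07 nM.

For the measured compounds named here, in an assay on ileum with muscarinic acetylcholine receptor M3 (Cavia porcellus) as the target (on this read-out higher numbers stand for weaker inhibition and lower numbers for stronger inhibition), compound 2 holds the lowest of the two numbers, and compound 1 is its only neighbour. Going by the values given here, the single measured step, an 18-fold lower number from compound 1 to compound 2 (1.24 log units; beyond the scatter), concerns the chain carbon and not the five-membered ring. Compound 3 is `CC(C)(C)c1nccn1CCC(C(N)=O)(c1ccccc1)c1ccccc1`. It differs from compound 2 by tert-butyl in place of hydrogen on an aromatic carbon, the new group sitting between two ring nitrogen atoms. Among the compounds with values here, no measured step touches that ring, and the carbamoyl step offers no guide to size or direction here. Compound 3 is therefore expected to move by only a 1.6-fold higher number from compound 2 to compound 3 (0.20 log units; within the scatter), giving an estimated 8 nM, with a range from 2 nM to 30 nM.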

Compound 3, antagonist equilibrium constant: 30.2 nM
For compound 3 the middle estimate is 3.8-fold (0.58 log units) below the measured one, and the stated range ends below it.
By their numbers in this assay, from the lowest: compound 2; then compound 3; then compound 1.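

Tert-butyl in place of hydrogen on the aromatic carbon between two ring nitrogen atoms gives a 6.0-fold higher number from compound 2 to compound 3 (0.77 log units; beyond the scatter) in this assay. For the compounds shown here, this is the first measured change on the five-membered ring, and it shows that the number responds to what sits at this position, here moving towards weaker inhibition. Nothing measured here explains the shift.

A methyl group or an amine on this same carbon would show whether the rise belongs to tert-butyl itself or to any replacement of the hydrogen there.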